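The source may hold more compounds than are shown below. What is called first, only, known or untested is meant among the compounds shown, and "the series" means these compounds.

Measured in an ADME assay on MT4 cells (Homo sapiens) for cytotoxicity, read by MTT assay, with a stated time of 4 days; a higher number here means that more compound is tolerated, a lower number that less compound is tolerated:
compound 1 `Cc1cc(-c2ccccc2)cc(C)c1Nc1ccnc(Nc2ccc(C#N)cc2)n1` — 4170 nM
compound 2 `Cc1cc(-c2cccc(F)c2)cc(C)c1Nc1ccnc(Nc2ccc(C#N)cc2)n1` — 4120 nM
compound 3 `Cc1cc(-c2ccccc2F)cc(C)c1Nc1ccnc(Nc2ccc(C#N)cc2)n1` — 2120 nM

Compound 3 carries the lowest of the three numbers in this assay, yet neither step to it clears the scatter: a 2.0-fold lower number from compound 1 to compound 3 (0.29 log units; within the scatter) and a 1.9-fold lower number from compound 2 to compound 3 (0.29 log units; within the scatter). Compound 4 `COc1cccc(-c2cc(C)c(Nc3ccnc(Nc4ccc(C#N)cc4)n3)c(C)c2)c1` differs from compound 3 by 3-methoxyphenyl in place of 2-fluorophenyl on an aromatic carbon. For the measured compounds named here, no measured step exchanges a fluorophenyl for a methoxyphenyl; the steps that bear on it are the other swaps on the same distal ring, a 1.0-fold lower number from compound 1 to compound 2 (0.01 log units; within the scatter) and a 1.9-fold lower number from compound 2 to compound 3 (0.29 log units; within the scatter), all within the scatter. A step in this assay beyond the scatter is therefore not expected, in either direction. Compound 4 is estimated at 3000 nM, range 1400 nM to 6500 nM. The expected step is a 1.4-fold higher number from compound 3 to compound 4 (0.15 log units; within the scatter).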

Compound 4, half-maximal cytotoxic concentration: 2990 nM
For compound 4 the middle estimate is 1.0-fold (0.00 log units) above the measured one; the measured number falls inside the stated range.
By their numbers in this assay, from the lowest: compounds 3, 4, 2 and 1 (each within the scatter of the next).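

3-Methoxyphenyl is the only ring shown here that brings an oxygen and a hydrogen-bond acceptor, yet in this assay the number stays within the scatter of all three earlier compounds (a 1.4-fold lower number from compound 1 to compound 4 (0.14 log units; within the scatter)) and (a 1.4-fold lower number from compound 2 to compound 4 (0.14 log units; within the scatter)) and (a 1.4-fold higher number from compound 3 to compound 4 (0.15 log units; within the scatter)). Across these four compounds, this position thus accepts hydrogen, fluoro and methoxy on the aromatic ring with no step beyond the scatter.

On these data alone, whether an amine, a carboxylic acid or a longer chain on this ring would give such a step stays open. Nothing available bears on the cause of these small steps.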